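Replacing the Acid Side Chain of Compound 2

The source may report more compounds than this note shows. Statements on the series, on what has been measured and on what is new or still open speak of the compounds shown alone.

Measured so far:
- compound 1 `COc1cc(C2CN(C(=O)c3cc(OCCCC(=O)O)ccn3)C2)ccc1OCc1ccc(C2CC2)cc1`: 100%
- compound 2 `COc1cc(C2CN(C(=O)c3cc(OCCCC(C)(C)C(=O)O)ccn3)C2)ccc1OCc1ccc(C2CC2)cc1`: 64%

In an ADME assay on S9 fraction from liver (Rattus norvegicus, strain Sprague-Dawley) for metabolic stability, read by LC-MS, using NADPH, with stated times of 5 min and 60 min, tested at 5 uM (a lower number here means that less of the compound is left, a higher number that more of the compound is left), compound 2 has the lower of the two numbers, 64%, while compound 1 reaches 100%. Within the data shown here, only one measured step is available, and it is large and beyond the scatter: a number 36 percentage points lower from compound 1 to compound 2 (beyond the scatter). It put 1-carboxy-1-methylethyl in place of carboxy on the side chain, so it shows that a modest edit to this chain can move the number a long way.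

The next change is bigger. Going from compound 2 to compound 3 `COc1cc(C2CN(C(=O)c3cc(COCC(CO)CO)ccn3)C2)ccc1OCc1ccc(C2CC2)cc1` puts (3-hydroxy-2-(hydroxymethyl)propoxy)methyl in place of (4-carboxy-4-methylpentyl)oxy on an aromatic carbon. Among the measured compounds shown here, no measured compound carries the entering group, so the one known step warns of possible movement but gives no firm direction. The change is expected to be small, with real uncertainty, and is estimated as a number 6 percentage points higher from compound 2 to compound 3 (within the scatter). The estimate for compound 3 is 70%, with an expected range from 40% to 95%.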

Compound 3, percent of the compound remaining: 29%
Beside the measured number, compound 3's estimate is 41 percentage points above it; measured number outside the range, below it.
By their numbers in this assay, from the lowest: compound 3; then compound 2; then compound 1.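

In this assay, exchanging the whole side chain at this aromatic carbon, opposite the ring nitrogen, gives a number 35 percentage points lower from compound 2 to compound 3 (beyond the scatter) once (3-hydroxy-2-(hydroxymethyl)propoxy)methyl replaces (4-carboxy-4-methylpentyl)oxy. Set against the unbranched acid chain 3-carboxypropoxy, the same entering group gives a number 71 percentage points lower from compound 1 to compound 3 (beyond the scatter) and leaves compound 3 lowest of the three, so both chains that end in a carboxy group stand above this chain with its two hydroxyl groups, though three compounds are a very small set. Nothing available explains why the number fell.

This exchange alters several things at once: the carboxy group goes, the hydroxyl groups arrive, and the chain is joined to the aromatic carbon through a methyl carbon rather than through an oxygen, so the compounds shown cannot separate these parts. Also open, as far as these compounds go, is how the number would respond at this place to a chain ending in an amine or a primary amide, or to a chain with a single hydroxyl group.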